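This account rests on a few compounds, and the source may have more. Where it says the series, first, only, none or still open, it means among the compounds named here.

Compound 1 `O=C1CCCN1c1cccc(C(=O)N(c2ncccc2Cl)[C@@H]2CCCNC2)c1` and compound 2 `O=C1CCCCN1c1cccc(C(=O)N(c2ncccc2Cl)[C@@H]2CCCNC2)c1` share one core; in a physicochemical assay for lipophilicity, at pH 7.4 (on this read-out higher numbers stand for higher lipophilicity and lower numbers for lower lipophilicity), compound 1 gives -0.5 and compound 2 gives -0.9. Between them stands one change, (2-oxopiperidin-1-yl in place of 2-oxopyrrolidin-1-yl on an aromatic carbon), and in this assay it made a number 0.40 log units lower from compound 1 to compound 2 (beyond the scatter). Compound 3 `O=C([C@@H]1C[C@H]1c1cccc(N2CCCC2=O)c1)N1CCN(C2CCC2)CC1` rests on a different core; how the two cores differ is not broken down here. In this assay compound 3 gives 2, the highest of the three numbers. Compound 4 `O=C([C@@H]1C[C@H]1c1cccc(N2CCCCC2=O)c1)N1CCN(C2CCC2)CC1` has not yet been measured. It differs from compound 3 by 2-oxopiperidin-1-yl in place of 2-oxopyrrolidin-1-yl on an aromatic carbon, the same change as that from compound 1 to compound 2, at the same place. Going by the values given here, because the step of a number 0.40 log units lower from compound 1 to compound 2 (beyond the scatter) is the only guide, the step in this assay is expected to be a number 0.40 log units lower from compound 3 to compound 4 (beyond the scatter). Compound 4 is therefore estimated at 1.6, between 1.1 and 2.1.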

Compound 4, distribution coefficient: 1.6
Compound 4: the middle estimate sits on the measured number at the digits printed; low and high end bracket the measured number.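

In this assay, putting 2-oxopiperidin-1-yl in place of 2-oxopyrrolidin-1-yl gave a number 0.40 log units lower from compound 3 to compound 4 (beyond the scatter), the same size as the earlier step, a number 0.40 log units lower from compound 1 to compound 2 (beyond the scatter), so the change carried over between these two cores. This rests on just two pairs, and it does not show that the step would hold on any further core or in any other read-out. Nothing at hand bears on why the step takes this size.

The compounds shown leave open how the lipophilicity read-out would respond to a different group on that aromatic carbon, such as an acetamide or a carboxylic acid. They also leave open whether either group would shift by a similar amount on both cores.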